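The source may hold more compounds than are shown below. What is called first, only, known or untested is meant among the compounds shown, and "the series" means these compounds.

Three amides that share one core have been measured in a physicochemical assay, with a stated time of 30 min; a higher number here means a weaker inhibitor, a lower number a stronger inhibitor. Compound 1 `COc1cc2c(cc1OC)C(=O)C(C(=O)Nc1ccccc1)C2` gives 61.3 ug/mL. Compound 2 `CCc1ccc(NC(=O)C2Cc3cc(OC)c(OC)cc3C2=O)cc1` gives 76.2 ug/mL. Compound 3 `COc1cc2c(cc1OC)C(=O)C(C(=O)Nc1ccc(F)cc1)C2` gives 55 ug/mL. Compound 2 sits beside the other two: the step of a 1.2-fold higher number from compound 1 to compound 2 (0.09 log units; within the scatter) and the step of a 1.4-fold lower number from compound 2 to compound 3 (0.14 log units; within the scatter) are both within the scatter, as is the step of a 1.1-fold lower number from compound 1 to compound 3 (0.05 log units; within the scatter), so none of the three can be told apart on these numbers.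

Compound 4 `COc1cc2c(cc1OC)C(=O)C(C(=O)Nc1cccc(Br)c1)C2` is not yet measured. It differs from compound 2 in one place: 3-bromophenyl in place of 4-ethylphenyl on an amide-type nitrogen. Among the measured compounds shown here, no measured step swaps in a bromine, and none changes the place on the ring, so the three steps just given are the only guide; each of them, an ethyl or a fluoro entering or leaving, stayed within the scatter. The number for compound 4 is therefore expected to stay close to that of compound 2, with a step of a 1.2-fold lower number from compound 2 to compound 4 (0.07 log units; within the scatter) that is not expected to exceed the scatter. Compound 4 is estimated at 65 ug/mL, with a likely range from 32 ug/mL to 130 ug/mL in this assay .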

Compound 4, half-maximal inhibitory concentration: 58.9 ug/mL
Compound 4: middle estimate off by 1.1-fold (0.04 log units), on the high side; the measured number falls inside the stated range.
By their numbers in this assay, from the lowest: compounds 3, 4, 1 and 2 (each within the scatter of the next).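

In this assay, bromo on the aromatic ring stays within the scatter of hydrogen, as the step of a 1.0-fold lower number from compound 1 to compound 4 (0.02 log units; within the scatter) shows, so bromo joins ethyl and fluoro among the groups that cannot be told apart from hydrogen here. Among the compounds shown here, this is also the first comparison in which the ring position of the group differs, yet neither a 1.3-fold lower number from compound 2 to compound 4 (0.11 log units; within the scatter) nor a 1.1-fold higher number from compound 3 to compound 4 (0.03 log units; within the scatter) exceeds the scatter, so 3-bromophenyl on the amide-type nitrogen cannot be separated from the other two substituted rings. No supporting evidence bears on why these four amides read alike.

On these data alone, all four compounds carry an aromatic ring on that nitrogen, so whether an amine, a carboxylic acid or a longer chain there would move the number beyond the scatter stays open. As far as these compounds go, what a change to the shared core would do also remains open.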